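Chain Lengthening on a Shared Imidazole-Phenol Scaffold

This account rests on a few compounds, and the source may have more. Where it says the series, first, only, none or still open, it means among the compounds named here.

Compound 1 `C=CCCCCOc1ccccc1-c1cnc(OCCCC=C)n1C` and compound 2 `C=CCCCCCOc1ncc(-c2ccccc2OCCCCC=C)n1C` share one core, and compound 3 `C=CCCOc1ncc(-c2ccccc2OC)n1C` and compound 4 `C=CCCCCOc1ncc(-c2ccccc2OC)n1C` share another; the difference between the two cores is not broken down here. In a functional assay on T98G cells (Homo sapiens) for inhibition, read by colorimetric assay and MTT assay, with a stated time of 72 h (on this read-out higher numbers stand for weaker inhibition and lower numbers for stronger inhibition), compound 1 gives 3000 nM, compound 2 gives 63000 nM, and compound 3 gives 39000 nM. The change from compound 1 to compound 2 is but-3-en-1-yl in place of vinyl on a saturated chain carbon, three bonds along the chain from an oxygen on an aromatic ring, and it made a 21-fold higher number from compound 1 to compound 2 (1.32 log units; beyond the scatter). Compound 4 carries the same kind of change relative to compound 3, namely (but-3-en-1-yl in place of vinyl on a saturated chain carbon, two bonds along the chain from an oxygen on an aromatic ring); the place is not identical, since here the chain carbon lies two bonds along the chain from the oxygen rather than three. Because compound 1 to compound 2 showed a 21-fold higher number from compound 1 to compound 2 (1.32 log units; beyond the scatter), a weakening of similar direction is expected for compound 4, although the different place and core leave its size uncertain. Compound 4 is therefore estimated at 120000 nM, with an expected step of a 3.1-fold higher number from compound 3 to compound 4 (0.49 log units; beyond the scatter) and a range of 35000 nM to 400000 nM in this assay.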

Compound 4, half-maximal inhibitory concentration: 5000 nM
For compound 4 the middle estimate is 24-fold (1.38 log units) above the measured one; measured number below the stated range.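

In this assay, putting but-3-en-1-yl in place of vinyl gave a 7.8-fold lower number from compound 3 to compound 4 (0.89 log units; beyond the scatter), which on this read-out means stronger inhibition. The same kind of change therefore did not carry over from one core to the other, and even its direction reversed: the same change on two cores in this assay, a 21-fold higher number (1.32 log units; beyond the scatter) from compound 1 to compound 2 and a 7.8-fold lower number (0.89 log units; beyond the scatter) from compound 3 to compound 4, 160-fold (2.21 log units) apart, beyond the scatter of two such steps. This does not show that the core alone sets the outcome, as the change sits three bonds along the chain from the oxygen in the first pair and two bonds along in the second, and a single pair on each core cannot separate these two differences or explain the reversal.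

On these data alone, what a saturated hexyl chain would do in place of the hex-5-en-1-yl chain of compound 4 remains open, and so does the role of the double bond at the chain end. Also open, as far as these compounds go, is whether a longer chain, such as oct-7-en-1-yl, would strengthen inhibition further on the core of compound 3 or weaken it.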